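The compounds below may be only part of what the source reports. "The series", "measured", "known", "first", "only" and "open" are said of these compounds alone.

Going by the values given here, in a functional assay on DLD-1 cells (Homo sapiens) for cytotoxicity, with a stated time of 48 h (a lower number here means a stronger inhibitor, a higher number a weaker inhibitor), compound 1 `CCCCOc1ccc2oc(/C=C/[S+](C)[O-])cc(=O)c2c1` gives 4800 nM and compound 2 `C[S+]([O-])/C=C/c1cc(=O)c2cc(Cl)ccc2o1` gives 6500 nM, so compound 2 stands within the scatter of the only other measured number. Compound 3 `C[S+]([O-])/C=C/c1cc(=O)c2cc(C#N)ccc2o1` carries one change from compound 2: cyano in place of chloro on an aromatic carbon. Among the compounds with values here, only one measured step bears on this, also a swap of a group on an aromatic carbon: a 1.4-fold higher number from compound 1 to compound 2 (0.13 log units; within the scatter). On that single step, no change beyond the scatter is expected in this assay, in either direction. For compound 3 the estimated value is 6000 nM, with an expected range of 2500 nM to 15000 nM.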

Compound 3, half-maximal inhibitory concentration: > 10000 nM
Compound 3: a limit, no number (the forecaster's own chance of this, stated with the estimate: 3%); middle value at least 1.6-fold (0.22 log units) away from the limit.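

In this assay, going by these compounds alone, compound 3 is a limit and not a number, the only such reading among the three: the limit of > 10000 nM in this assay, at which 1 of the 3 values shown sits. Within the data shown here, this aromatic carbon is therefore not indifferent to its group: cyano in place of butoxy gives an at least 2.0-fold higher number from compound 1 to compound 3 (0.31 log units; beyond the scatter), the first step beyond the scatter. Cyano in place of chloro gives an at least 1.5-fold higher number from compound 2 to compound 3 (0.18 log units; that floor lies within the scatter), so that swap alone is not shown to matter. As far as these compounds go, the true size of both steps stays open, and so does how an amine or a carboxylic acid would read on this aromatic carbon.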